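The compounds below may be only part of what the source reports. "The series", "measured", "known", "first", "only" and "open" are said of these compounds alone.

Measured so far in a functional assay on the whole organism (plasma, strain Wistar) with Rattus norvegicus as the target, with a stated time of 15 days, at a dose of 30 mg/kg by the oral route; on this read-out higher numbers stand for a stronger effect at the one dose given and lower numbers for a weaker effect:
compound 1, `Cc1nc(COc2ccc(/C=C3\SC(=O)NC3=O)cc2)cs1`, gives 14.7%
compound 2, `O=C1NC(=O)/C(=C/c2ccc(OCCSc3nnc(-c4ccc(Br)cc4)[nH]3)cc2)S1`, gives 19.5%
compound 3, `O=C1NC(=O)/C(=C/c2ccc(OCCSc3nnc(-c4ccccc4)o3)cc2)S1`, gives 16.1%

For the measured compounds named here, all three numbers lie close together, and the set holds no pair of measured compounds that differ in a single place, so no step between measured compounds is available. Compound 3 holds the second highest of the three numbers. Its nearest neighbour is compound 1, whose value sits within the scatter of that of compound 3, and the furthest is compound 2, whose value also sits within the scatter. No order among the three can be read from these numbers.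

The next compound, compound 4, `O=C1NC(=O)/C(=C/c2ccc(OCCSc3nnc(Cc4ccccc4)o3)cc2)S1`, differs from compound 3 in a single place: benzyl in place of phenyl on an aromatic carbon. Nothing in the measured set shows what a change of this kind does on this read-out, so the step expected in this assay is none beyond the scatter: a number 0.1 percentage points lower from compound 3 to compound 4 (within the scatter). On that basis compound 4 is expected to give 16%, with a range from 7% to 26%.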

Compound 4, a percentage reported as activity, at one dose (the size of the read-out at that dose, not a potency): 19.1%
Estimate against measurement, compound 4: 3.1 percentage points below; measured number inside the range.
By their numbers in this assay, from the lowest: compounds 1, 3, 4 and 2 (each within the scatter of the next).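

In this assay, for the compounds shown here, benzyl in place of phenyl on an aromatic carbon of the five-membered ring gives a number 3 percentage points higher from compound 3 to compound 4 (within the scatter) and this is the first step that compares two compounds differing in one place. At this position, the exchange of phenyl for benzyl therefore leaves the read-out within the scatter at the one dose given. No measurement here bears on the reason for this result.

On these data alone, whether an amine, a carboxylic acid or a longer chain such as phenylethyl at this position would move the read-out beyond the scatter remains open. Also open, as far as these compounds go, is whether a substituent such as bromine on the benzene ring of the benzyl group would have any effect in compound 4.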